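A Methoxyethyl Chain in Place of Isopropyl

The source may hold more compounds than are shown below. What is called first, only, known or untested is meant among the compounds shown, and "the series" means these compounds.

Three compounds share one core. Compound 1 `CCC(OC)C1=C(N2CC2)C(=O)C(C)=C(N2CC2)C1=O` gives 5.68 in a functional assay on L1210 cells (Mus musculus), with a stated time of 12 days (a higher number here means a more potent compound, by a factor of ten per unit of this negative logarithm, a lower number a less potent compound), compound 2 `CC1=C(N2CC2)C(=O)C(C2CCCCC2)=C(N2CC2)C1=O` gives 5.82, and compound 3 `CC1=C(N2CC2)C(=O)C(C(C)C)=C(N2CC2)C1=O` gives 5.6. Compound 3 carries the smallest of the three numbers, yet its gaps to the others, a number 0.08 log units lower from compound 1 to compound 3 (within the scatter) and a number 0.22 log units lower from compound 2 to compound 3 (within the scatter), both stay within the scatter, so the three cannot be told apart. Compound 4 `COCCC1=C(N2CC2)C(=O)C(C)=C(N2CC2)C1=O` differs from compound 3 in one place: 2-methoxyethyl in place of isopropyl on a double-bonded ring carbon. The measured step that bears most on this is a number 0.08 log units lower from compound 1 to compound 3 (within the scatter), where a methoxy-bearing chain gave way to isopropyl without a change beyond the scatter; a number 0.22 log units lower from compound 2 to compound 3 (within the scatter) likewise stayed within it. The reverse move is therefore expected to leave the number essentially unchanged, a number 0.10 log units higher from compound 3 to compound 4 (within the scatter). Compound 4 is thus estimated at 5.7, within 5.3 to 6.1.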

Compound 4, logarithm of the reciprocal of the active concentration, log(1/C): 5.57
Estimate against measurement, compound 4: 0.13 log units above, and the stated range covers the measured number.
By their numbers in this assay, from the lowest: compounds 4, 3, 1 and 2 (each within the scatter of the next).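

In this assay the 2-methoxyethyl chain brings an oxygen and a hydrogen-bond acceptor to this double-bonded ring carbon, yet the step from isopropyl is a number 0.03 log units lower from compound 3 to compound 4 (within the scatter) and no change can be read from it. The comparisons with the other two groups give a number 0.25 log units lower from compound 2 to compound 4 (within the scatter) and a number 0.11 log units lower from compound 1 to compound 4 (within the scatter) as well, so all four groups at this position, with or without oxygen, cannot be told apart. Nothing on hand explains this lack of difference. On these data alone, whether an amine or a carboxylic acid on this carbon would stay equally close remains open.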